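A second bromo on compound 2

A few compounds are considered here, and "the series" means these few. Any claim that something is new, unique, unknown or untested is made for them only; others in the source may bear on it.

In an ADME assay for permeability, using PAMPA, at pH 7.4 (a lower number here means that the compound crosses the layer more slowly, a higher number that the compound crosses the layer faster), compound 1 (`Cc1[nH]c2ccccc2c(=O)c1C1CCCCC1`) gives 230 10^-6 cm/s. Compound 3 (`Cc1[nH]c2ccccc2c(=O)c1/C=C/c1ccc(O)cc1`) gives 17 10^-6 cm/s, and compound 2 (`Cc1[nH]c2ccccc2c(=O)c1Br`) gives 13.6 10^-6 cm/s. These last two lie within the scatter of each other, so compound 2 shares the low end of this small set. Compound 4 (`Cc1[nH]c2ccc(Br)cc2c(=O)c1Br`) has not been measured. It differs from compound 2 in one place: bromo in place of hydrogen on an aromatic carbon. Among the compounds with values here, only one measured step bears on this change, and it is large and beyond the scatter: a 17-fold lower number from compound 1 to compound 2 (1.23 log units; beyond the scatter), with bromo in place of cyclohexyl. Within the data shown here, that step is a loose guide, since no measured pair shows a bromo replacing hydrogen. Compared with the bromo of compound 2, the group of compound 1 is bigger, and compound 1 reads 230 10^-6 cm/s, so a small upward move is expected, far short of that large step. The expected step is a 1.6-fold higher number from compound 2 to compound 4 (0.21 log units; within the scatter), which may not clear the scatter. For compound 4 the estimated value is 22 10^-6 cm/s, with an expected range from 8 10^-6 cm/s to 60 10^-6 cm/s.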

Compound 4, apparent permeability: 95.3 10^-6 cm/s
Compound 4: middle estimate off by 4.3-fold (0.64 log units), on the low side; the whole stated range lies below it.
By their numbers in this assay, from the lowest: compounds 2 and 3 (each within the scatter of the next); then compound 4; then compound 1.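

In this assay, within the data shown here, the new step shows that a place the earlier compounds left as hydrogen, on the six-membered aromatic ring of carbon only, can also move the read-out: bromo in place of hydrogen gives a 7.0-fold higher number from compound 2 to compound 4 (0.85 log units; beyond the scatter) as its result. Among these compounds, compounds 1, 2 and 3 differ from one another at a single other place on the shared core, so this is the first measured change at a second place, and it involves only one added heavy atom. Nothing available here explains why the number rises with this change.

As far as these compounds go, it remains open whether the rise belongs to bromo itself or would also appear with a chloro, a methoxy or an amine at the same place. From the compounds shown here alone, it is also open whether the same added bromo would raise the number when compound 1's cyclohexyl, rather than compound 2's bromo, sits at the other place.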